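This account rests on a few compounds, and the source may have more. Where it says the series, first, only, none or still open, it means among the compounds named here.

Compound 1 `COc1cccc(CN2C(=O)CN(C(=O)c3cc4cc(OC)ccc4[nH]3)C[C@@H]2COCc2ccccc2)c1` gives 11700 nM in a physicochemical assay for solubility, read by spectrophotometry, in phosphate buffer, with a stated time of 2 h, at pH 7.4; a higher number here means a more soluble compound, a lower number a less soluble compound.
Compound 2 `COc1ccc2[nH]c(C(=O)N3CC(=O)N(Cc4ccccc4)[C@@H](COCc4ccccc4)C3)cc2c1` gives 8800 nM in this assay.
Compound 3 `COc1ccc2[nH]c(C(=O)N3CC(=O)N(Cc4cccc(OC)n4)[C@@H](Cc4ccccc4)C3)cc2c1` gives 47500 nM in this assay.

Of these three, compound 3 stands highest in this assay, beyond the scatter above both compound 1 and compound 2. Compound 4 `COc1ccc2[nH]c(C(=O)N3CC(=O)N(Cc4cc5ccccc5[nH]4)[C@@H](Cc4ccccc4)C3)cc2c1` differs from compound 3 in one place: 1H-indol-2-yl in place of 6-methoxypyridin-2-yl on a saturated chain carbon bound to an amide-type nitrogen in a ring. Going by the values given here, no measured pair shows this exact change. Among the compounds with values here, the only measured step, a 1.3-fold lower number from compound 1 to compound 2 (0.12 log units; within the scatter), removes a methoxy from a different aromatic ring and stays within the scatter, so it gives little guidance for swapping one whole ring system for another. The change from compound 3 to compound 4 replaces a methoxy-bearing six-membered ring with a fused two-ring system, a larger alteration than anything measured here, so a step beyond the scatter in this assay seems plausible, most likely downward, though the direction is not secured by data. Compound 4 is therefore expected to give about 14000 nM, within 4500 nM to 40000 nM, a step of a 3.4-fold lower number from compound 3 to compound 4 (0.53 log units; beyond the scatter).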

Compound 4, solubility: 11000 nM
The estimate for compound 4 lay 1.3-fold (0.10 log units) above the measured number; the range from low to high includes it.
By their numbers in this assay, from the lowest: compounds 2, 4 and 1 (each within the scatter of the next); then compound 3.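

In this assay, the place on a saturated chain carbon bound to an amide-type nitrogen in a ring proves sensitive to the ring it carries: 1H-indol-2-yl in place of 6-methoxypyridin-2-yl gives a 4.3-fold lower number from compound 3 to compound 4 (0.64 log units; beyond the scatter). Going by these compounds alone, the only earlier step between compounds differing in one place, hydrogen in place of methoxy on an aromatic carbon, stayed within the scatter, so this is the first such change here to move the number clearly. The swap alters the ring types, hetero atoms, and hydrogen-bond donors and acceptors together, and nothing available explains the step or separates these features. Still open, going by these compounds, is whether a plain pyridin-2-yl, without the methoxy, would stay near compound 3 or fall toward compound 4. On these data alone, how a ring carrying a carboxylic acid or an amine would read at this place in this assay also remains open.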